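The source may report more compounds than this note shows. Statements on the series, on what has been measured and on what is new or still open speak of the compounds shown alone.

Compound 1 `OCCOCCOCCOc1ccc(OCc2ccccc2)cc1`: 59400 nM
Compound 2 `Nc1cccc(COc2ccc(OCCOCCNC3CCCC3)cc2)c1`: 10800 nM

Both compounds were tested in a functional assay on SK-OV-3 cells (Homo sapiens) for inhibition, read by CCK-8 assay, with a stated time of 70 h; a lower number here means a stronger inhibitor, a higher number a weaker inhibitor. Compound 2 holds the lower of the two numbers, and the gap to compound 1 lies beyond the scatter. Compound 3 `O=[N+]([O-])c1cccc(COc2ccc(OCCOCCNC3CCCC3)cc2)c1` has not yet been measured. It carries nitro in place of amino on an aromatic carbon. Within the data shown here, no measured pair shows this change, so the data offer no direct guide. No shift beyond the scatter is expected, and the estimated change is a 1.1-fold higher number from compound 2 to compound 3 (0.05 log units; within the scatter). For compound 3 the expected value is 12000 nM, with an estimated range from 4500 nM to 32000 nM.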

Compound 3, half-maximal inhibitory concentration: 15400 nM
For compound 3 the middle estimate is 1.3-fold (0.11 log units) below the measured one; the range from low to high includes it.
By their numbers in this assay, from the lowest: compounds 2 and 3 (each within the scatter of the next); then compound 1.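

In this assay, among these compounds, placing nitro in place of amino on this aromatic carbon gives a 1.4-fold higher number from compound 2 to compound 3 (0.15 log units; within the scatter), the first direct reading of any change at this position. The exchange of 3-aminophenyl for 3-nitrophenyl, which removes the hydrogen-bond donor of the amino group, therefore produces no shift beyond the scatter in these cells. Nothing available explains why the two groups read alike. The compounds shown leave open whether a nitrile, a carboxylic acid or an acetamide on this same carbon would move the number beyond the scatter.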